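Trimming the Cyclohexyl Group from Compound 1

The compounds below may be only part of what the source reports. "The series", "measured", "known", "first", "only" and "open" are said of these compounds alone.

Compound 1 `Cn1cc(-c2ccc(NC(=O)c3cn(CC4CCCCC4)cc(-c4ccc(F)cc4)c3=O)cc2)c2c(N)ncnc21` shows a value of 2.3 nM in an assay on isolated protein for inhibition of tyrosine-protein kinase receptor UFO (Homo sapiens), read by ELISA; a lower number here means a stronger inhibitor, a higher number a weaker inhibitor. Compound 2 `Cn1cc(-c2ccc(NC(=O)c3cn(CC4CCOCC4)cc(-c4ccc(Cl)cc4)c3=O)cc2)c2c(N)ncnc21` gives 0.2 nM in this assay, so compound 1 holds the higher of the two numbers, and that gap lies beyond the usual scatter. Compound 3 `Cn1cc(C(=O)Nc2ccc(-c3cn(C)c4ncnc(N)c34)cc2)c(=O)c(-c2ccc(F)cc2)c1` is reached from compound 1 by one change: hydrogen in place of cyclohexyl on a saturated chain carbon bound to an aromatic nitrogen. Going by the values given here, no measured pair shows this step, so the expectation rests on the change alone. The step from compound 1 to compound 3 is expected to raise the number beyond the scatter, by about a 13-fold higher number from compound 1 to compound 3 (1.12 log units; beyond the scatter). Compound 3 is therefore estimated at 30 nM, within a range of 5 nM to 200 nM.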

Compound 3, half-maximal inhibitory concentration: 5 nM
Compound 3: middle estimate off by 6.0-fold (0.78 log units), on the high side; low and high end bracket the measured number.
By their numbers in this assay, from the lowest: compound 2; then compound 1; then compound 3.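

Trimming cyclohexylmethyl to methyl, at the place bound to an aromatic nitrogen, gives in this assay a 2.2-fold higher number from compound 1 to compound 3 (0.34 log units; beyond the scatter). This modest step shows that the cyclohexyl group is not essential here: without it, compound 3 still gives 5 nM. No measurement shown explains why the loss is this small.

Going by these compounds, how an amine, a carboxylic acid or a longer chain would fare at this place remains open. Compound 2 differs from compound 1 in more than one place, so its lower number cannot be assigned to any single change.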